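The compounds below may be only part of what the source reports. "The series", "measured", "known", "first", "only" and "open" are said of these compounds alone.

Compound 2 `OC(CCn1nc2c(Br)c(Br)c(Br)c(Br)c2n1)c1ccccc1` carries the shared core with a phenyl on a saturated chain carbon bound to an oxygen on a saturated carbon. In a functional assay on MCF7 cells (Homo sapiens) for antiproliferative activity, read by MTT assay, with a stated time of 24 h, tested at 25 uM (on this read-out higher numbers stand for a weaker effect at the one concentration tested and lower numbers for a stronger effect), compound 2 gives 99%, the highest of the two numbers recorded, which means almost no effect on the cells at the one concentration tested. Compound 1 `OC(CCn1nc2c(Br)c(Br)c(Br)c(Br)c2n1)c1cccc(Cl)c1` differs only by a chloro on an aromatic carbon. In this assay compound 1 gives 96%, and the step of a number 3 percentage points higher from compound 1 to compound 2 (within the scatter) lies within the scatter. Compound 3 `CC(O)CCn1nc2c(Br)c(Br)c(Br)c(Br)c2n1` is the next change: methyl in place of phenyl on a saturated chain carbon bound to an oxygen on a saturated carbon and a saturated chain carbon. Within the data shown here, no measured step touches this position, so the only guide is that the one change tried so far left the read-out unchanged and that both numbers sit close to no effect. Compound 3 is therefore expected to give 96%, within 85% to 104%, an expected step of a number 3 percentage points lower from compound 2 to compound 3 (within the scatter) that stays within the scatter.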

Compound 3, a percentage reported as activity, at one concentration (the size of the read-out at that concentration, not a potency): 102%
Compound 3: middle estimate off by 6 percentage points, on the low side; the range from low to high includes it.
By their numbers in this assay, from the lowest: compounds 1, 2 and 3 (each within the scatter of the next).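

Replacing the phenyl with a methyl on a saturated chain carbon bound to an oxygen on a saturated carbon and a saturated chain carbon gives a number 3 percentage points higher from compound 2 to compound 3 (within the scatter) in this assay, and replacing the 3-chlorophenyl with the same methyl gives a number 6 percentage points higher from compound 1 to compound 3 (within the scatter) in the same read-out. At this position, then, a group with a six-membered aromatic ring of carbon only and a single-carbon group with no ring cannot be told apart, and all three compounds stay close to no effect at the one concentration tested. Nothing measured here offers an explanation for this.

From the compounds shown here alone, whether an amine, a carboxylic acid or a longer chain at this position would give a stronger effect remains open. Going by these compounds, because the shared core is the same in all three compounds, the effect of changing the core also remains open.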